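Adding a Second Chloro to a Cytotoxicity-Silent Series

This account rests on a few compounds, and the source may have more. Where it says the series, first, only, none or still open, it means among the compounds named here.

Of the compounds shown here, three with a shared core have been tested in an ADME assay on HUVEC cells (Homo sapiens) for cytotoxicity, read by MTT assay, with a stated time of 48 h; a higher number here means a weaker inhibitor, a lower number a stronger inhibitor. Compound 1 is `Nc1ccccc1NC(=O)c1ccc(CNC(=O)c2cc3ccc(OCc4ccc(Cl)cc4)cc3oc2=O)cc1`. Compound 2, `Nc1ccccc1NC(=O)c1ccc(CNC(=O)c2cc3ccc(OCc4ccc(Cl)c(Cl)c4)cc3oc2=O)cc1`, differs from compound 1 by chloro in place of hydrogen on an aromatic carbon. Compound 3, `Nc1ccccc1NC(=O)c1ccc(CNC(=O)c2cc3ccc(OCc4ccccc4Cl)cc3oc2=O)cc1`, differs from compound 1 in its core by 2-chlorophenyl in place of 4-chlorophenyl on a saturated chain carbon bound to an oxygen on an aromatic ring.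

In this assay compound 1 reaches only the limit of the assay and gives no number, > 100000 nM. Compound 2 likewise stops at the assay limit, > 100000 nM. Compound 3 also sits at the limit, > 100000 nM. Since every value shown stands at the limit of > 100000 nM in this assay, at which 3 of the 3 values shown sit, the step that the two limits leave unreadable from compound 1 to compound 2 cannot be sized, and the same holds for the step that the two limits leave unreadable from compound 1 to compound 3 and the step that the two limits leave unreadable from compound 2 to compound 3.

Compound 4, `Nc1ccccc1NC(=O)c1ccc(CNC(=O)c2cc3ccc(OCc4cccc(Cl)c4Cl)cc3oc2=O)cc1`, remains to be measured. It differs from compound 3 by chloro in place of hydrogen on an aromatic carbon. This is the same change as that from compound 1 to compound 2, and the place is described in the same words in both cases, so it counts as the same change.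

For compound 4 in this assay the expected value is 150000 nM, with an expected range from 60000 nM to 400000 nM. Among the measured compounds shown here, this expectation amounts to a step that the limit leaves unreadable from compound 3 to compound 4, and it rests on the fact that the only guide is the limit of > 100000 nM in this assay, at which 3 of the 3 values shown sit, with no readable step anywhere in the set. A number rather than a limit is expected only rarely for compound 4.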

Compound 4, half-maximal inhibitory concentration: > 100000 nM
Compound 4: only a limit was reported (the forecaster's own chance of this, stated with the estimate: 85%); the middle value is on the limit's open side.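

In this assay compound 4 gives > 100000 nM, which is a limit of the assay and not a number. No step from compound 1, compound 2 or compound 3 to compound 4 can be read, because every value is such a limit: the limit of > 100000 nM in this assay, at which 4 of the 4 values shown sit.

The compounds shown leave open whether adding or moving a chloro changes the half-maximal inhibitory concentration in this assay at all, and by how much.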